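The source may report more compounds than this note shows. Statements on the series, on what has been measured and on what is new or still open speak of the compounds shown alone.

In a functional assay on PC-3 cells (Homo sapiens) for cytotoxicity, read by MTT assay, with a stated time of 72 h (on this read-out lower numbers stand for stronger inhibition and higher numbers for weaker inhibition), compound 1 `COc1ccc2nc(NC(=O)c3cn(-c4ccccc4)nc3-c3ccccc3)sc2c1` gives 17500 nM. Compound 2 `COc1ccc2nc(NC(=O)c3cn(-c4ccccc4)nc3-c3ccc(F)cc3)sc2c1` carries the change (fluoro in place of hydrogen on an aromatic carbon), and in this assay compound 2 gives 12800 nM, a step of a 1.4-fold lower number from compound 1 to compound 2 (0.14 log units; within the scatter). Compound 3 `COc1ccc(-c2nn(-c3ccccc3)cc2C(=O)Nc2nc3ccccc3s2)cc1` has the same atoms as compound 1, joined differently; the difference between the two cores is not broken down here. In this assay compound 3 gives 6670 nM. Compound 4 `COc1ccc(-c2nn(-c3ccccc3)cc2C(=O)Nc2nc3ccc(F)cc3s2)cc1` differs from compound 3 by fluoro in place of hydrogen on an aromatic carbon, the same kind of change as that from compound 1 to compound 2 but not the same: there the fluorine sat on a six-membered aromatic ring of carbon only, para to a large group, here it sits on a ring that is part of a fused or bridged system of two rings, meta and para to a fused ring. Because the earlier step was a 1.4-fold lower number from compound 1 to compound 2 (0.14 log units; within the scatter), a step of about a 1.3-fold lower number from compound 3 to compound 4 (0.13 log units; within the scatter) is expected from compound 3 to compound 4 in this assay. Compound 4 is therefore estimated at 5000 nM, between 2500 nM and 12000 nM.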

Compound 4, half-maximal inhibitory concentration: 4930 nM
Compound 4: middle estimate off by 1.0-fold (0.01 log units), on the high side; the range from low to high includes it.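

In this assay, fluoro in place of hydrogen on the benzothiazole of compound 3 gives a 1.4-fold lower number from compound 3 to compound 4 (0.13 log units; within the scatter). Set beside the earlier fluoro step, the two agree: the same change on two cores in this assay, a 1.4-fold lower number (0.14 log units; within the scatter) from compound 1 to compound 2 and a 1.4-fold lower number (0.13 log units; within the scatter) from compound 3 to compound 4, 1.0-fold (0.00 log units) apart, within the scatter of two such steps This shows that the change has a similarly small size on these two cores, even with the fluorine on a different ring in each pair, but with both steps within the scatter, it does not show that fluoro has a real effect on either core.

The compounds shown leave open whether a larger group in the same place, such as an amine or a carboxylic acid, would give a step beyond the scatter. They also leave open whether chloro would track fluoro from one core to the other.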